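One Inverted Stereocentre and Oral Bioavailability in Rat

The compounds below may be only part of what the source reports. "The series", "measured", "known", "first", "only" and "open" are said of these compounds alone.

Of the compounds shown here, two have so far been measured in an in vivo ADME assay on the whole organism (strain Sprague-Dawley) for pharmacokinetics, with Rattus norvegicus as the target, at a dose of 1 mg/kg by the oral route; a lower number here means that a smaller share of the oral dose reaches the circulation, a higher number that a larger share of the oral dose reaches the circulation. Compound 1 `CNc1c(-c2ccc(=O)n(-c3ccccc3C)n2)c(-c2ccc(F)cc2)nn1C` gives 28.6%, and compound 2 `Cc1ccccc1-n1nc(-c2c(-c3ccc(F)cc3)nn3c2NC[C@@H](O)C3)ccc1=O` gives 67.7%. Compound 2 therefore stands highest of the two, and its gap to compound 1 lies beyond the scatter. The two compounds differ in more than one place, so this gap cannot be assigned to any single structural feature.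

Compound 3 `Cc1ccccc1-n1nc(-c2c(-c3ccc(F)cc3)nn3c2NC[C@H](O)C3)ccc1=O` is the next to be examined (the two compounds have the same atoms and bonds and differ only in configuration as drawn: 1 of 1 stereo elements differ; a stereocentre at a saturated ring carbon is drawn R in compound 2 and S in compound 3). It has the same atoms and bonds as compound 2 and differs only in configuration as drawn: a stereocentre at a saturated ring carbon is drawn R in compound 2 and S in compound 3. For the measured compounds named here, no measured pair shows what a change of configuration alone does in this assay, so the expectation rests on compound 2 at 67.7%, and no step beyond the scatter is expected. The expected step is a number 5.7 percentage points lower from compound 2 to compound 3 (within the scatter), with a slight lean downward and considerable uncertainty. For compound 3 the estimate is 62%, with an expected range from 38% to 85%.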

Compound 3, oral bioavailability: 81%
Compound 3: the middle estimate sits 19 percentage points below what was measured; the measured number falls inside the stated range.
By their numbers in this assay, from the lowest: compound 1; then compound 2; then compound 3.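

In this assay, for the compounds shown here, turning the stereocentre at a saturated ring carbon from R to S comes with a number 13.3 percentage points higher from compound 2 to compound 3 (beyond the scatter) and gives the first reading of a single structural change. Compound 1 and compound 2 differ in more than one place, so their gap could not show that this stereocentre matters on its own, whereas this pair shows that the share of the oral dose reaching the circulation in rat responds to configuration here, even with every atom and bond unchanged. The step can be assigned to the inverted stereocentre and to nothing else because of one structural fact: the fact that compounds 2 and 3 differ only in the configuration as drawn.

The pair does not show how configuration acts on oral bioavailability, and this single modest step rests on one pair of compounds, so it sets no rule for other members of the series. It also leaves open whether S would still give the higher number if the hydroxyl on this ring carbon gave way to an amine or a methoxy group, with each configuration compared in the same way.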